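The compounds below may be only part of what the source reports. "The series", "measured", "known", "first", "only" and "open" are said of these compounds alone.

Of the compounds shown here, three of a shared core have been measured in a functional assay on NCI-H460 cells (Homo sapiens) for antiproliferative activity, read by XTT assay, with a stated time of 72 h; on this read-out lower numbers stand for stronger inhibition and higher numbers for weaker inhibition. Compound 1 `COc1ccc(C(=O)/C=C/c2nc3ccccc3cc2-c2ccc(OC)cc2)cc1` reaches only a limit there: compound 1 gives > 10000 nM, which is a limit and not a number. Compound 2 `COc1ccc(-c2cc3ccccc3nc2/C=C/C(=O)c2ccc(N)cc2)cc1` gives 7400 nM in this assay, and compound 3 `COc1ccc(-c2cc3ccccc3nc2/C=C/C(=O)c2ccccn2)cc1` gives 6260 nM. The change from compound 1 to compound 2 amounts to an at least 1.3-fold lower number from compound 1 to compound 2 (0.13 log units; that floor lies within the scatter), from compound 1 to compound 3 to an at least 1.5-fold lower number from compound 1 to compound 3 (0.20 log units; that floor lies within the scatter), and from compound 2 to compound 3 to a 1.2-fold lower number from compound 2 to compound 3 (0.07 log units; within the scatter). Among the two numbers shown, compound 3 has the lowest, with compound 2 close beside it within the scatter.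

Compound 4 `COc1ccc(-c2cc3ccccc3nc2/C=C/C(=O)c2cnc(N)nc2C)cc1` differs from compound 3 by 2-amino-4-methylpyrimidin-5-yl in place of pyridin-2-yl on a carbonyl carbon. The two measured steps that touch the same carbonyl carbon, from compound 1 to compound 3 and from compound 2 to compound 3, were both small or within the scatter, so a step beyond the scatter is not expected here; the estimated step from compound 3 to compound 4 is a 1.1-fold lower number from compound 3 to compound 4 (0.06 log units; within the scatter). Compound 4 is therefore expected to give about 5500 nM in this assay, with a likely range from 2000 nM to 15000 nM.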

Compound 4, half-maximal inhibitory concentration: > 10000 nM
Compound 4: a limit, no number; the forecaster's own chance of this, stated with the estimate: 20%; middle value at least 1.8-fold (0.25 log units) away from the limit.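

In this assay compound 4 gives > 10000 nM, which is a limit and not a number. On this carbonyl carbon, 2-amino-4-methylpyrimidin-5-yl brings no gain, with an at least 1.5-fold higher number from compound 3 to compound 4 (0.20 log units; that floor lies within the scatter) and an at least 1.3-fold higher number from compound 2 to compound 4 (0.13 log units; that floor lies within the scatter); since both floors lie within the scatter, they show no clear loss either, and the step from compound 1 to compound 4 cannot be read. Four groups have now stood on this carbon, none giving a number lower than those of compound 2 and compound 3, and the results crowd against one edge of the read-out: the limit of > 10000 nM in this assay, at which 2 of the 4 values shown sit.

From the compounds shown here alone, it remains open whether any group on this carbonyl carbon can give a step beyond the scatter. A methyl group or a carboxylic acid there would show whether an aromatic ring on this carbon matters at all.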